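Swapping Carboxy for Methylsulfanyl on the Aryl Urea

The source may hold more compounds than are shown below. What is called first, only, known or untested is meant among the compounds shown, and "the series" means these compounds.

Compound 1 `O=C(Nc1ccccc1Cl)N[C@H]1CC[C@H](Oc2ccc(F)cc2)CC1` carries a 2-chlorophenyl on one urea nitrogen. In a functional assay on CRL2813 cells (Homo sapiens) for cytotoxicity, read by sulforhodamine B assay, with a stated time of 5 days (on this read-out lower numbers stand for stronger inhibition and higher numbers for weaker inhibition), compound 1 gives 9100 nM. Compound 2 `O=C(Nc1cccc(C(=O)O)c1)N[C@H]1CC[C@H](Oc2ccc(F)cc2)CC1` carries a 3-carboxyphenyl in that place instead. In this assay compound 2 gives > 20000 nM, which is a limit of the assay rather than a number. The step of an at least 2.1-fold higher number from compound 1 to compound 2 (0.34 log units; beyond the scatter) thus rests on (the limit of > 20000 nM in this assay, at which 1 of the 2 values shown sits), and compound 2 is known only to sit at or beyond that limit. Compound 3 `CSc1cccc(NC(=O)N[C@H]2CC[C@H](Oc3ccc(F)cc3)CC2)c1` is compound 2 with one change: methylsulfanyl in place of carboxy on an aromatic carbon. Going by the values given here, the only measured step that bears on this change is an at least 2.1-fold higher number from compound 1 to compound 2 (0.34 log units; beyond the scatter), in which entry of the carboxy group raised the number; its removal in compound 3 is expected to bring the number back down by a modest amount, although the limit leaves the true size uncertain. Compound 3 is therefore expected to give 10000 nM, with a range of 3500 nM to 30000 nM, a step of an at least 2.0-fold lower number from compound 2 to compound 3 (0.30 log units; that floor lies within the scatter) in this assay.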

Compound 3, half-maximal inhibitory concentration: 11100 nM
Compound 3: middle estimate off by 1.1-fold (0.05 log units), on the low side; low and high end bracket the measured number.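

In this assay, methylsulfanyl in place of carboxy gives an at least 1.8-fold lower number from compound 2 to compound 3 (0.25 log units; that floor lies within the scatter), a floor that by itself does not go beyond the scatter. Going by these compounds, the true size of this step stays unknown, since compound 2 is known only through a limit of the assay: the limit of > 20000 nM in this assay, at which 1 of the 3 values shown sits. The clearer reading comes from the other step, a 1.2-fold higher number from compound 1 to compound 3 (0.09 log units; within the scatter), which shows that 3-(methylsulfanyl)phenyl and 2-chlorophenyl cannot be told apart here, whereas 3-carboxyphenyl gave a rise beyond the scatter, so that rise does not follow from every group placed on this ring.

On these data alone, whether an amine or a methoxy group in the same place would stay close to compound 3 or move toward compound 2 remains open. As far as these compounds go, how far compound 2 truly lies beyond its limit also remains open.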